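Quinoline bis-thioether series: selenium swap and chain shortening

The compounds below may be only part of what the source reports. "The series", "measured", "known", "first", "only" and "open" are said of these compounds alone.

Measured compounds in a functional assay on P388 cells (Mus musculus) for cytotoxicity, read by MTT assay, with a stated time of 72 h; on this read-out lower numbers stand for stronger inhibition and higher numbers for weaker inhibition:
compound 1, `OCC#CCSc1cnc2ccccc2c1[Se]CC#CCO`, 4.1 ug/mL
compound 2, `OCC#CCSc1cnc2ccccc2c1SCC#CCO`, 5.7 ug/mL

Compound 1 gives the lowest of the two numbers in this assay; compound 2 sits at the next value, and the step of a 1.4-fold higher number from compound 1 to compound 2 (0.14 log units; within the scatter) lies within the scatter, so the two cannot be ordered on the data.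

Compound 3, `C#CCSc1c(SCC#CCO)cnc2ccccc12`, has not yet been measured. It differs from compound 1 by a group of 4 heavy atoms (3 carbon, 1 sulfur; no ring) in place of a group of 6 heavy atoms (4 carbon, 1 oxygen, 1 selenium; no ring), on an aromatic carbon. Among the compounds with values here, the group that leaves is the same one that was exchanged in the only measured step, so the step of a 1.4-fold higher number from compound 1 to compound 2 (0.14 log units; within the scatter) bears on it; that step was within the scatter. Within the data shown here, the group that enters, propargylsulfanyl, is shorter and carries no hydrogen-bond donor, and no measured pair speaks to such a change, so its effect is unknown.

Given this, compound 3 is expected to move only modestly, if at all, and the estimated step is a 1.7-fold higher number from compound 1 to compound 3 (0.23 log units; within the scatter). Compound 3 is estimated at 7 ug/mL, with a range from 3 ug/mL to 18 ug/mL.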

Compound 3, concentration for 50% inhibition: 13.3 ug/mL
Estimate against measurement, compound 3: 1.9-fold (0.28 log units) below; measured number inside the range.
By their numbers in this assay, from the lowest: compounds 1 and 2 (each within the scatter of the next); then compound 3.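

In this assay, within the data shown here, the chain end gives the first change that lies beyond the scatter: hydrogen in place of hydroxymethyl on a triple-bonded carbon produces a 2.3-fold higher number from compound 2 to compound 3 (0.37 log units; beyond the scatter) and is the more direct reading, since sulfur stands on the aromatic carbon on both sides of the step. Set against the selenium-bearing chain, propargylsulfanyl produces a 3.2-fold higher number from compound 1 to compound 3 (0.51 log units; beyond the scatter) and is also a modest change, so this aromatic carbon accepts the shorter chain with only somewhat weaker inhibition, whereas the exchange of selenium for sulfur alone could not be told from the scatter. No supporting data bear on why the number rises at this position.

Whether the hydroxyl itself or the length of the chain accounts for the step stays open, as a methyl group, an aminomethyl group or a longer hydroxyalkyl chain on the triple-bonded carbon would be needed to separate the two. Also open, on these data alone, is whether the same shortening on the chain at the other aromatic carbon gives a step of similar size, and whether selenium in place of sulfur matters once the chain is shortened.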